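Working notes on a group swap in one amide series

The source may hold more compounds than are shown below. What is called first, only, known or untested is meant among the compounds shown, and "the series" means these compounds.

Measured so far in an ADME assay on cells (Hepatocyte, Rattus norvegicus) for metabolic stability, using equilibrium dialysis; a higher number here means faster removal of the compound, a lower number slower removal:
compound 1 `CC(=O)N[C@@H]1CCC[C@H](C(=O)Nc2cc(-c3cnn(C)c3C)c(Cl)cn2)C1`: 10 uL/min
compound 2 `CC(=O)N[C@@H]1CCC[C@H](C(=O)Nc2cc(-c3cnc4n3CCCC4)c(Cl)cn2)C1`: 12 uL/min
compound 3 `CC(=O)N[C@@H]1CCC[C@H](C(=O)Nc2cc(-c3cnn4c3NCCC4)c(Cl)cn2)C1`: 10 uL/min

Compound 2 sits among the other two rather than apart from them: there is a 1.2-fold higher number from compound 1 to compound 2 (0.08 log units; within the scatter) and a 1.2-fold lower number from compound 2 to compound 3 (0.08 log units; within the scatter), and between the outer pair no change at the digits printed from compound 1 to compound 3 (within the scatter). The three numbers in this assay are therefore not distinguishable from one another.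

Compound 4 `CC(=O)N[C@@H]1CCC[C@H](C(=O)Nc2cc(-c3cnn4c3OCCC4)c(Cl)cn2)C1` has not yet been measured. Against compound 2 the change is a group of 9 heavy atoms (6 carbon, 2 nitrogen, 1 oxygen; one five-membered aromatic ring with 2 hetero atoms, one six-membered non-aromatic ring with 2 hetero atoms) in place of a group of 9 heavy atoms (7 carbon, 2 nitrogen; one five-membered aromatic ring with 2 hetero atoms, one six-membered non-aromatic ring with 1 hetero atom), on an aromatic carbon. Going by the values given here, the measured step that bears most directly on it is the one from compound 2 to compound 3, which also replaced the group on that aromatic carbon with another of the same size and came out as a 1.2-fold lower number from compound 2 to compound 3 (0.08 log units; within the scatter); the step of a 1.2-fold higher number from compound 1 to compound 2 (0.08 log units; within the scatter), a replacement at the same place, was likewise within the scatter. Nothing among the three compounds shows this position moving the number beyond the scatter, so in this assay no step beyond the scatter is expected for compound 4.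

The expected step is a 1.1-fold lower number from compound 2 to compound 4 (0.04 log units; within the scatter). Compound 4 is estimated at 11 uL/min, with a range from 6 uL/min to 22 uL/min.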

Compound 4, intrinsic clearance in a liver preparation (reported as CLH), per the amount of preparation that the assay uses: 34 uL/min
Compound 4: the middle estimate sits 3.1-fold (0.49 log units) below what was measured; measured number outside the range, above it.
By their numbers in this assay, from the lowest: compounds 1, 3 and 2 (each within the scatter of the next); then compound 4.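

In this assay this position, opposite the ring nitrogen and ortho to the chloro group, can move the number beyond the scatter: the change gives a 2.8-fold higher number from compound 2 to compound 4 (0.45 log units; beyond the scatter) and a 3.4-fold higher number from compound 3 to compound 4 (0.53 log units; beyond the scatter) and also a 3.4-fold higher number from compound 1 to compound 4 (0.53 log units; beyond the scatter) in a series where no earlier replacement at this place had left the scatter. The step from compound 3 is the narrowest comparison, as the two groups carry the same ring types and differ by one nitrogen exchanged for one oxygen, so a change in a single atom of the six-membered non-aromatic ring is enough to separate compound 4 from compound 3, and size of the group alone does not set the number here. Nothing in the data explains the rise.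

As far as these compounds go, it remains open whether the higher number goes with the ring oxygen specifically or would also appear with a ring sulfur or a ring methylated amine in its place. From the compounds shown here alone, it is also open whether the same exchange of nitrogen for oxygen would give a similar step with a five-membered or seven-membered ring fused in place of the six-membered non-aromatic ring.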